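The source may hold more compounds than are shown below. What is called first, only, known or untested is meant among the compounds shown, and "the series" means these compounds.

Compound 1 `CSc1ccc(NC(=O)Nc2cc(C)nc3ccccc23)cc1` gives 1300 nM in a physicochemical assay for solubility, at pH 7.4; on this read-out higher numbers stand for higher solubility and lower numbers for lower solubility.
Compound 2 `Cc1cc(NC(=O)Nc2ccc3[nH]cnc3c2)c2ccccc2n1` gives 7300 nM in this assay.
Compound 3 `Cc1cc(NC(=O)Nc2ncccc2C)c2ccccc2n1` gives 1300 nM in this assay.

Compound 1 stands level with compound 3 at the digits shown, the two together the lowest of the three numbers; compound 2 sits furthest from compound 1, with a higher number that lies beyond the usual scatter. The step to compound 4 `COc1ccc(NC(=O)Nc2cc(C)nc3ccccc23)cc1` is a small exchange on the outer ring: methoxy in place of methylsulfanyl on an aromatic carbon. Going by the values given here, no measured pair carries this exchange, so there is no direct guide to its size. From the closeness of compound 1 and compound 3, only a modest shift is expected, probably upward but within the scatter. The step is estimated as a 1.5-fold higher number from compound 1 to compound 4 (0.19 log units; within the scatter). Compound 4 is therefore expected to give about 2000 nM, in a range from 800 nM to 5000 nM.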

Compound 4, solubility: 19800 nM
The estimate for compound 4 lay 9.9-fold (1.00 log units) below the measured number; measured number above the stated range.
By their numbers in this assay, from the lowest: compounds 1 and 3 (each within the scatter of the next); then compound 2; then compound 4.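

Exchanging sulfur for oxygen in the group on this aromatic carbon, para to a large group, is enough to produce a large change in this assay: methoxy in place of methylsulfanyl gives a 15-fold higher number from compound 1 to compound 4 (1.18 log units; beyond the scatter). The two groups have the same counts of heavy atoms, hydrogen-bond donors and acceptors, and neither carries a net charge, so these counts do not predict the difference. No measurement shown accounts for this step. As far as these compounds go, whether an ethoxy group, a hydroxyl group or an amine at this position would give a similar number remains open. So does whether the same exchange would have a similar effect on a different core.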